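The source may report more compounds than this note shows. Statements on the series, on what has been measured and on what is new or still open speak of the compounds shown alone.

In a functional assay on HL-60 cells (Homo sapiens) for antiproliferative activity, read by MTT assay, with a stated time of 72 h (on this read-out higher numbers stand for weaker inhibition and lower numbers for stronger inhibition), compound 1 `COc1cc(-c2ncnn2-c2cccc(F)c2)cc(OC)c1OC` gives > 10000 nM, which is a limit and not a number. Compound 2 `COc1cc(-c2ncnn2-c2ccc(Cl)cc2Cl)cc(OC)c1OC` gives > 10000 nM, which is also a limit. Compound 3 `COc1cc(-c2ncnn2-c2ccc([N+](=O)[O-])cc2)cc(OC)c1OC` gives > 10000 nM, and this too is a limit. For the measured compounds named here, the whole series so far therefore comes down to one observation: the limit of > 10000 nM in this assay, at which 3 of the 3 values shown sit. Compound 3 has no measured potency from which to count.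

Compound 4 `COc1cc(-c2ncnn2-c2ccc(N)cc2)cc(OC)c1OC` has amino in place of nitro on an aromatic carbon, para to a large group: amino in place of nitro on an aromatic carbon. Going by the values given here, the one measured step, a step that the two limits leave unreadable from compound 1 to compound 2, offers no size to carry over, and it involves neither nitro nor amino. With so little to go on, the default expectation is that compound 4 stays weak in this assay, although a readable number could only lie on the stronger side of the limit. The expected step is a number no higher from compound 3 to compound 4 (the limit leaves the size open), and its true size may remain unreadable. For compound 4 the estimated value is 10000 nM, with an expected range from 2000 nM to 30000 nM.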

Compound 4, half-maximal inhibitory concentration: > 10000 nM
Compound 4: a limit, no number; the forecaster's own chance of this, stated with the estimate: 70%; the middle value lies on the limit itself.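

No step can be read among compound 1, compound 2, compound 3 and compound 4, since each gives only a limit and not a number: the limit of > 10000 nM in this assay, at which 4 of the 4 values shown sit.

Left open is how potent any of these compounds truly is, and whether any change to the group on the aromatic nitrogen would give a readable number in this assay at all.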